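This account rests on a few compounds, and the source may have more. Where it says the series, first, only, none or still open, it means among the compounds named here.

Measured so far:
- compound 1, `O=C(O)c1cc2cc(-c3ccccc3)n(O)c2cc1C(=O)O` — 23300 nM in an assay on isolated protein for inhibition of Amine oxidase [flavin-containing] A (Homo sapiens), read by fluorescence and spectrophotometry, with a stated time of 20 min; on this read-out lower numbers stand for stronger inhibition and higher numbers for weaker inhibition
- compound 2, `Cc1ccc(-c2cc3cc(C(=O)O)c(C(=O)O)cc3n2O)cc1` — > 100000 nM in this assay

Compound 2 stands at the edge of what the numbers shown can tell: its value in this assay is a limit, (the limit of > 100000 nM in this assay, at which 1 of the 2 values shown sits), not a number. For the measured compounds named here, compound 1 is the only one with a real number. Going by the values given here, the single measured step runs an at least 4.2-fold higher number from compound 1 to compound 2 (0.63 log units; beyond the scatter), so the step out of compound 1 and up to the limit is the whole of what is known about the shared core.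

Compound 3, `COc1ccc(-c2cc3cc(C(=O)O)c(C(=O)O)cc3n2O)cc1`, is not yet measured. It differs from compound 2 by methoxy in place of methyl on an aromatic carbon. Among the compounds with values here, no measured pair shows a methoxy anywhere, and no measured pair shows a swap of one group for another at this position, so the step from compound 1 to compound 2 bears on it only loosely, as the one sign that a substituent at this site did not help.

The expectation for compound 3 in this assay is therefore a step that the limit leaves unreadable from compound 2 to compound 3, meaning a value near the limit again, and compound 3 is estimated at 120000 nM, with a range from 30000 nM to 500000 nM.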

Compound 3, half-maximal inhibitory concentration: > 100000 nM
Compound 3: only a limit was reported (the forecaster's own chance of this, stated with the estimate: 60%); the middle value lies beyond the limit too.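

In this assay compound 3 gives > 100000 nM, which is a limit and not a number. Methoxy in place of hydrogen on the aromatic carbon gives an at least 4.2-fold higher number from compound 1 to compound 3 (0.63 log units; beyond the scatter); read with an at least 4.2-fold higher number from compound 1 to compound 2 (0.63 log units; beyond the scatter), this means two different groups at this position, methyl and methoxy, now both move the number up beyond the scatter, and none of the three compounds goes against this. The step from compound 2 to compound 3 cannot be read, so methyl and methoxy cannot be put in order against each other: the limit of > 100000 nM in this assay, at which 2 of the 3 values shown sit.

For the compounds shown here, how far past the limit compound 2 and compound 3 lie stays open, and compound 1 remains the only real number from which to judge the series. Also open, as far as these compounds go, is whether the loss belongs to every group at this position or only to these two, a question that fluorine, a hydroxyl, an amine or a carboxylic acid in the same place on the shared core would address.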